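Amino to Methyl on a Thiadiazole Linked to Two Chromone Cores

A few compounds are considered here, and "the series" means these few. Any claim that something is new, unique, unknown or untested is made for them only; others in the source may bear on it.

Compound 2 `Nc1nnc(SCc2cc(=O)c3ccccc3o2)s1` and compound 1 `Cc1nnc(SCc2cc(=O)c3ccccc3o2)s1` share one core and differ only in that methyl replaces amino (methyl in place of amino on an aromatic carbon). In a functional assay on MDA-MB-435S cells (Homo sapiens) for cytotoxicity, read by MTT assay, with a stated time of 72 h (on this read-out lower numbers stand for stronger inhibition and higher numbers for weaker inhibition), compound 2 reaches only the limit of the assay, > 25000 nM. In this assay compound 1 also reaches only that limit, > 25000 nM. The step that the two limits leave unreadable from compound 2 to compound 1 therefore cannot be read, since both values sit at the limit of > 25000 nM in this assay, at which 2 of the 3 values shown sit. Compound 3 `Nc1nnc(SCc2coc3ccccc3c2=O)s1` has the same atoms as compound 2 joined differently; the difference between the two cores is not broken down here. In this assay, within the data shown here, compound 3 gives 950 nM, the only number among the three. Compound 4 `Cc1nnc(SCc2coc3ccccc3c2=O)s1` is the not yet measured partner of compound 3, made by the same change, methyl in place of amino (methyl in place of amino on an aromatic carbon), at a place described in the same words as for compound 1 and compound 2. Because the measured instance of this change is hidden by the limit of > 25000 nM in this assay, at which 2 of the 3 values shown sit, nothing shows its size. Compound 4 is expected to lie near compound 3, with the step of a 2.1-fold higher number from compound 3 to compound 4 (0.32 log units; beyond the scatter) taken as small, so the estimate for compound 4 is 2000 nM, between 600 nM and 10000 nM.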

Compound 4, half-maximal inhibitory concentration: 630 nM
Compound 4: the middle estimate sits 3.2-fold (0.50 log units) above what was measured, and the stated range covers the measured number.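

In this assay, changing 5-amino-1,3,4-thiadiazol-2-yl to 5-methyl-1,3,4-thiadiazol-2-yl gives a 1.5-fold lower number from compound 3 to compound 4 (0.18 log units; within the scatter), so on this core the change makes no difference that can be told from the ordinary spread of repeated measurements. The matching step on the other core cannot be read, because compound 1 and compound 2 both give a limit of the assay rather than a number: the limit of > 25000 nM in this assay, at which 2 of the 4 values shown sit. Among these compounds, with only one readable pair, the change has not really been tested across two cores, and nothing here shows whether it would also be small on the core of compound 1 or would differ there.

The compounds shown leave open whether a different group at this place, such as a carboxylic acid, a dimethylamine or a longer chain like propyl, would also leave the result on the core of compound 3 unchanged. They also leave open whether any such group would bring a measurable number on the core of compound 1.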